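Moving to 2,4-dichlorophenyl on the shared core

The source may hold more compounds than are shown below. What is called first, only, known or untested is meant among the compounds shown, and "the series" means these compounds.

In a functional assay on HeLa cells (Homo sapiens) for antiproliferative activity, read by MTT assay (on this read-out higher numbers stand for weaker inhibition and lower numbers for stronger inhibition), compound 1 `O=[N+]([O-])c1ccc(Nc2nccc(-c3ccc(Br)cc3)n2)cc1` gives 25700 nM, compound 2 `O=[N+]([O-])c1ccc(Nc2nccc(-c3ccc(F)cc3)n2)cc1` gives 3510 nM and compound 3 `O=[N+]([O-])c1ccc(Nc2nccc(-c3ccc(Cl)c(Cl)c3)n2)cc1` gives 1840 nM. Compound 3 shares the low end of these numbers with compound 2, and the two do not separate: a 1.9-fold lower number from compound 2 to compound 3 (0.28 log units; within the scatter). Compound 1 stands apart from both, with a modest step in a 7.3-fold lower number from compound 1 to compound 2 (0.86 log units; beyond the scatter) and a large one in a 14-fold lower number from compound 1 to compound 3 (1.15 log units; beyond the scatter).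

The next structure is compound 4 `O=[N+]([O-])c1ccc(Nc2nccc(-c3ccc(Cl)cc3Cl)n2)cc1`, which has the same atoms as compound 3, joined differently: 2,4-dichlorophenyl in place of 3,4-dichlorophenyl on an aromatic carbon. In words, 2,4-dichlorophenyl stands in place of 3,4-dichlorophenyl on an aromatic carbon of the shared core. Going by the values given here, no measured pair isolates this kind of change, so the evidence is indirect. The closest guide is a 1.9-fold lower number from compound 2 to compound 3 (0.28 log units; within the scatter), a change between two aryl groups that stays within the scatter. The larger steps all start from compound 1, and they keep the range wide. No step beyond the scatter is expected in this assay, with a slight lean towards a higher number. The expected step is a 1.6-fold higher number from compound 3 to compound 4 (0.21 log units; within the scatter). The estimate for compound 4 is 3000 nM, with an expected range of 1000 nM to 10000 nM.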

Compound 4, half-maximal inhibitory concentration: 168000 nM
For compound 4 the middle estimate is 56-fold (1.75 log units) below the measured one; the measured number lies above the stated range.
By their numbers in this assay, from the lowest: compounds 3 and 2 (each within the scatter of the next); then compound 1; then compound 4.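

In this assay the aryl position on the shared core proves sensitive to the arrangement of the chlorines alone: with the same atoms on both sides, 2,4-dichlorophenyl in place of 3,4-dichlorophenyl gives a 91-fold higher number from compound 3 to compound 4 (1.96 log units; beyond the scatter) while the earlier step between two aryl groups at the low end stayed within the scatter. The 2,4-dichlorophenyl group also stands clear of the other aryl groups shown, with a 48-fold higher number from compound 2 to compound 4 (1.68 log units; beyond the scatter) and a 6.5-fold higher number from compound 1 to compound 4 (0.82 log units; beyond the scatter) so that 4-bromophenyl no longer marks the high end of the series. Nothing measured here accounts for this shift in the read-out.

The compounds shown leave open whether the high number belongs to the 2,4-dichlorophenyl pattern as a whole or to one of its two chlorines; a monochlorophenyl group on the shared core would separate the two. On these data alone, how a methyl, a methoxy or an amine on the same aryl ring would read in this assay also remains open.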